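The compounds below may be only part of what the source reports. "The series", "measured", "known", "first", "only" and "open" are said of these compounds alone.

Of the compounds shown here, two with a shared macrocyclic core have been tested in a functional assay on MCF7 cells (Homo sapiens) for antiproliferative activity, read by MTT assay, with a stated time of 72 h; on this read-out lower numbers stand for stronger inhibition and higher numbers for weaker inhibition. Compound 1 `c1ccc(COc2ccccc2Nc2ncnc3cc4c(cc23)OCCOCCOCCO4)cc1` gives 63300 nM in this assay. Compound 2 `FC(F)(F)c1ccc(COc2ccc(Nc3ncnc4cc5c(cc34)OCCOCCOCCOCCO5)cc2)cc1` gives 10000 nM in this assay, the lower of the two numbers and therefore the stronger inhibition, with the gap to compound 1 lying beyond the usual scatter of repeated measurements.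

Compound 3 `O=[N+]([O-])c1ccc(COc2ccc(Nc3ncnc4cc5c(cc34)OCCOCCOCCOCCO5)cc2)cc1` has not yet been measured. It differs from compound 2 in one place: nitro in place of trifluoromethyl on an aromatic carbon. For the measured compounds named here, no pair of measured compounds shows this change, so its effect here is not known from the data in hand.

Because compound 2 gives 10000 nM and the rest of the molecule is unchanged, compound 3 is expected to stay close to it, with the step from compound 2 to compound 3 estimated as a 1.3-fold lower number from compound 2 to compound 3 (0.10 log units; within the scatter), not beyond the scatter in either direction. Compound 3 is estimated at 8000 nM in this assay, within a range from 2500 nM to 25000 nM.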

Compound 3, half-maximal inhibitory concentration: > 100000 nM
Compound 3 gave a limit, no number; the forecaster's own chance of this, stated with the estimate: 10%; at least 12-fold (1.09 log units) between middle value and limit.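

For the compounds shown here, compound 1 and compound 2 differ in more than one place, so this is the first direct look at the group on this aromatic carbon, and in this assay replacing trifluoromethyl with nitro is far from a neutral exchange: it gives an at least 10-fold higher number from compound 2 to compound 3 (1.00 log units; beyond the scatter). Compound 3 reads > 100000 nM, which is a limit of the assay and not a number. The step is thus a minimum, and its full size remains unknown: the limit of > 100000 nM in this assay, at which 1 of the 3 values shown sits.

The compounds shown leave open whether this weakening is particular to nitro or would also appear with other groups at this position, such as an amine, a carboxylic acid or a methyl. They also do not show whether the same exchange would have a similar effect on the core of compound 1.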